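Swapping the aromatic group beside the ring amine

The source may hold more compounds than are shown below. What is called first, only, known or untested is meant among the compounds shown, and "the series" means these compounds.

Compound 3 `O=C(NC1CCN(Cc2cccc(C(F)(F)F)c2)CC1)c1ccc2ccccc2c1` is the starting point. Among the measured compounds shown here, in an assay on isolated protein for displacement of a labelled ligand from D(4) dopamine receptor (Homo sapiens) (a higher number here means a weaker inhibitor, a lower number a stronger inhibitor), compound 3 gives 103 nM, the lowest of the three numbers measured so far. Compound 2 `O=C(NC1CCN(Cc2cccc(C(F)(F)F)c2)CC1)c1cccc2ccccc12` gives 119 nM in this assay, and the step of a 1.2-fold lower number from compound 2 to compound 3 (0.06 log units; within the scatter) shows that exchanging naphthalen-1-yl for naphthalen-2-yl on the carbonyl carbon made no real difference. For the measured compounds named here, compound 1 `O=C(NC1CCN(Cc2ccccc2Cl)CC1)c1cccc2ccccc12` gives 329 nM in this assay, and the step of a 2.8-fold lower number from compound 1 to compound 2 (0.44 log units; beyond the scatter) is the one measured change at the saturated chain carbon bound to the amine nitrogen in the ring.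

Compound 4 `Cc1ccc(CN2CCC(NC(=O)c3ccc4ccccc4c3)CC2)cc1` differs from compound 3 in one place: 4-methylphenyl in place of 3-(trifluoromethyl)phenyl on a saturated chain carbon bound to an amine nitrogen in a ring.

Going by the values given here, only the step from compound 1 to compound 2 bears on this change, since it altered the aromatic group at the same carbon and moved the number by a modest amount; there the 3-(trifluoromethyl)phenyl compound gave the lower number. Removing that group in favour of 4-methylphenyl is therefore expected to raise the number by a modest amount, though the data give no direct comparison of these two groups. Compound 4 is expected to give about 220 nM in this assay, within a range of 90 nM to 550 nM. This means an expected step of a 2.1-fold higher number from compound 3 to compound 4 (0.33 log units; beyond the scatter).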

Compound 4, inhibition constant: 21 nM
Compound 4: middle estimate off by 10-fold (1.02 log units), on the high side; measured number outside the range, below it.
By their numbers in this assay, from the lowest: compound 4; then compounds 3 and 2 (each within the scatter of the next); then compound 1.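

In this assay, the move to 4-methylphenyl gives a 4.9-fold lower number from compound 3 to compound 4 (0.69 log units; beyond the scatter), which shows that the trifluoromethyl group is not needed for a low number at this position and that a group with 7 heavy atoms and no fluorine can do better than one with 10 heavy atoms. The earlier change at this carbon, a 2.8-fold lower number from compound 1 to compound 2 (0.44 log units; beyond the scatter), had favoured 3-(trifluoromethyl)phenyl over 2-chlorophenyl, but that step was measured with naphthalen-1-yl on the carbonyl carbon, whereas the new step has naphthalen-2-yl there, and it could not show how a different aromatic group would compare. Nothing available here explains why the number fell when 4-methylphenyl came in.

This single step replaces the substituent on the phenyl ring and alters its numbered location together, so the two changes cannot be separated; 3-methylphenyl and 4-(trifluoromethyl)phenyl would be the groups that pull them apart. Also open, on these data alone, is whether other groups in the place of the methyl on 4-methylphenyl, such as an ethyl, a methoxy or an amine, would give a lower or a higher number.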